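Swapping 4-fluorophenyl for pyridin-3-yl on the saturated carbon

This account rests on a few compounds, and the source may have more. Where it says the series, first, only, none or still open, it means among the compounds named here.

compound 1 `CC(=O)N1N=C(c2ccc3ccccc3c2)OC1c1cccc(F)c1`: 1.61 ug/mL
compound 2 `CC(=O)N1N=C(c2ccc3ccccc3c2)OC1c1ccc(F)cc1`: 4.65 ug/mL
compound 3 `CC(=O)N1N=C(c2ccc3ccccc3c2)OC1c1cccnc1`: not yet measured

Going by the values given here, in a functional assay on B16-F10 cells (Mus musculus) for antiproliferative activity, read by MTT assay, with a stated time of 48 h (on this read-out higher numbers stand for weaker inhibition and lower numbers for stronger inhibition), compound 2 gives 4.65 ug/mL, the higher of the two numbers so far, and its only neighbour, compound 1, gives 1.61 ug/mL. The next change leads to compound 3: pyridin-3-yl in place of 4-fluorophenyl on a saturated ring carbon. Pyridin-3-yl takes the place of 4-fluorophenyl on a saturated ring carbon, and the shared core stays as it is.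

Among the compounds with values here, one measured step bears on this: a 2.9-fold higher number from compound 1 to compound 2 (0.46 log units; beyond the scatter). It is modest but beyond the scatter, and it concerns the group on the same carbon, exchanging 3-fluorophenyl for 4-fluorophenyl. It shows that this assay can register a change at this carbon. Within the data shown here, no measured compound carries pyridin-3-yl, so the data give no direction. A step no larger than that modest one is expected, in either direction, and it may not exceed the scatter. The estimated step is a 1.2-fold lower number from compound 2 to compound 3 (0.07 log units; within the scatter). Compound 3 is expected at 4 ug/mL, with an estimated range of 1.3 ug/mL to 13 ug/mL.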

Compound 3, half-maximal inhibitory concentration: 3.06 ug/mL
Beside the measured number, compound 3's estimate is 1.3-fold (0.12 log units) above it; the measured number falls inside the stated range.
By their numbers in this assay, from the lowest: compounds 1, 3 and 2 (each within the scatter of the next, the first and the last beyond it).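

In this assay the exchange at the saturated ring carbon gives a 1.5-fold lower number from compound 2 to compound 3 (0.18 log units; within the scatter) and the exchange against the other fluorophenyl group gives a 1.9-fold higher number from compound 1 to compound 3 (0.28 log units; within the scatter) so pyridin-3-yl cannot be told apart from either fluorophenyl group. Compound 3 therefore sits within the scatter of both neighbours, even though those two are separated beyond it by a 2.9-fold higher number from compound 1 to compound 2 (0.46 log units; beyond the scatter) and the carbon thus remains a place where this assay can register a change. A carbon-only aromatic ring bearing fluorine can give way to a six-membered aromatic ring with one ring nitrogen, which brings one hydrogen-bond acceptor, without a step beyond the scatter, and nothing available explains this outcome.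

The compounds shown leave open how a plain phenyl ring, or a phenyl ring carrying an aminomethyl group or a carboxylic acid, would compare at this carbon. They also leave open whether the ring nitrogen's place within the pyridine ring matters, and whether the result holds for any group other than these three aromatic rings.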